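The compounds below may be only part of what the source reports. "The series", "measured", "known", "first", "only" and "open" are said of these compounds alone.

Compound 1 `CCCCCCCCCCCC(=O)OC[C@H](CSC[C@@H](N)C(=O)NC(C)CCc1ccccc1)OC(=O)CCCCCCCCCCC` is the reference point of this pair. In an assay on HEK293 cells for agonist activity at Toll-like receptor 2 (Homo sapiens) (a higher number here means that more compound is needed for the effect, a lower number that less compound is needed), compound 1 gives 160 nM, the lowest of the two numbers recorded; compound 2 `CCCCCCCCCCCC(=O)OC[C@H](CSC[C@@H](N)C(=O)NCCCOCCOCCOCCCNC(=O)C(N)CS)OC(=O)CCCCCCCCCCC` gives 247 nM in this assay, within the scatter of compound 1, so the two show no order. Compound 3 `CCCCCCCCCCCC(=O)OC[C@H](CSC[C@@H](N)C(=O)NC(C)CCN(CC)CC)OC(=O)CCCCCCCCCCC` is not yet measured. Relative to compound 1 the change is diethylamino in place of phenyl on a saturated chain carbon, three bonds along the chain from an amide-type nitrogen. Among the measured compounds shown here, no measured step exists for this change, and compound 2 shows that a very different amide substituent leaves the number within the scatter, so for compound 3 a step of a 1.3-fold higher number from compound 1 to compound 3 (0.10 log units; within the scatter) is expected, not beyond the scatter. The expected value for compound 3 is 200 nM, in the range 80 nM to 600 nM.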

Compound 3, half-maximal effective concentration: 257 nM
Compound 3: the middle estimate sits 1.3-fold (0.11 log units) below what was measured; the range from low to high includes it.
By their numbers in this assay, from the lowest: compounds 1, 2 and 3 (each within the scatter of the next).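

At this position, on a saturated chain carbon, three bonds along the chain from an amide-type nitrogen, diethylamino in place of phenyl gives a 1.6-fold higher number from compound 1 to compound 3 (0.21 log units; within the scatter) in this assay. The phenyl ring is therefore not needed to keep the number within the scatter of compound 1, since a group with no ring and one nitrogen serves as well. No evidence on a cause accompanies this result.

Going by these compounds, whether a carboxylic acid at this place would stay within the scatter remains open. So does the outcome of a longer chain carrying the diethylamino group.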